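An Ethyl Ester Whose Number Is Still to Come

The source may report more compounds than this note shows. Statements on the series, on what has been measured and on what is new or still open speak of the compounds shown alone.

The study brings together three measured compounds, compound 1 `CCOC(=O)C1=Cc2ccccc2OC1(OCc1cc(-c2ccc3ccccc3c2)no1)C(F)(F)F`, compound 2 `CCOC(=O)C1=Cc2ccccc2OC1(OCc1cc(-c2ccc(OC)cc2)no1)C(F)(F)F` and compound 3 `O=C(O)C1=Cc2ccccc2OC1(OCc1cc(-c2ccc(F)cc2)no1)C(F)(F)F`, and one still to be measured, compound 4 `CCOC(=O)C1=Cc2ccccc2OC1(OCc1cc(-c2ccc(F)cc2)no1)C(F)(F)F`, all tested in a functional assay on HeLa cells (Homo sapiens) for inhibition, read by MTT assay, with a stated time of 24 h; a higher number here means a weaker inhibitor, a lower number a stronger inhibitor. In this assay compound 1 returns only a limit, > 150000 nM, not a number. Compound 2 likewise returns only a limit, > 150000 nM. Compound 3 also gives nothing but a limit, > 150000 nM. Within the data shown here, the single step that joins two measured compounds, a step that the two limits leave unreadable from compound 1 to compound 2, is therefore not readable in size. Compound 3 stands at the limit of > 150000 nM in this assay, at which 3 of the 3 values shown sit. Compound 4 differs from compound 3 by ethyl in place of hydrogen on an oxygen next to a carbonyl group. Among the measured compounds shown here, no measured step covers this change; the only reading that bears on it is that compound 1 and compound 2, both ethyl esters, sit at the same limit as compound 3. Compound 4 is therefore expected to stay at the limit, with an estimated step that the limit leaves unreadable from compound 3 to compound 4. The estimate for compound 4 is 200000 nM, ranging from 100000 nM to 500000 nM.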

Compound 4, half-maximal inhibitory concentration: 42300 nM
The estimate for compound 4 lay 4.7-fold (0.67 log units) above the measured number; measured number below the stated range.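

In this assay, ethyl in place of hydrogen on an oxygen next to a carbonyl group gives an at least 3.5-fold lower number from compound 3 to compound 4 (0.54 log units; beyond the scatter), so with the 4-fluorophenyl group present, the ethoxycarbonyl compound gives a readable number where the carboxy compound does not. The ester alone does not suffice: fluoro in place of methoxy gives an at least 3.5-fold lower number from compound 2 to compound 4 (0.54 log units; beyond the scatter), and 4-fluorophenyl in place of naphthalen-2-yl gives an at least 3.5-fold lower number from compound 1 to compound 4 (0.54 log units; beyond the scatter). Compound 1, compound 2 and compound 3 remain at a limit rather than a number: the limit of > 150000 nM in this assay, at which 3 of the 4 values shown sit.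

These steps therefore give only minimum sizes, and the steps among the compounds held at the limit cannot be read. As far as these compounds go, whether a propyl chain on this oxygen, an amide in place of the ester, or chloro in place of fluoro would keep or change the number remains open.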